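Removing the cyclohexyl from compound 1: working notes

The source may hold more compounds than are shown below. What is called first, only, known or untested is meant among the compounds shown, and "the series" means these compounds.

Measured compounds:
compound 1 `CCn1c(-c2ccccc2)nc2c(NC3CCCCC3)ncnc21`: 9020 nM
compound 2 `Cn1c(-c2ccc(C(=O)O)cc2)nc2c(NC3CCCC3)ncnc21`: a limit of the assay, > 30000 nM
compound 3 `COc1ccc(-c2nc3c(NC4CCCC4)ncnc3n2C)cc1`: a limit of the assay, > 30000 nM

Going by the values given here, in a functional assay on CHO cells for antagonist activity at adenosine receptor A2b (Homo sapiens), read by 33P incorporation, with a stated time of 20 min (a higher number here means a weaker inhibitor, a lower number a stronger inhibitor), compound 1 gives 9020 nM, the only number in the set. Compound 2 reaches only a limit of the assay, > 30000 nM. Compound 3 likewise reaches only a limit, > 30000 nM. Among the compounds with values here, the one step between measured compounds, a step that the two limits leave unreadable from compound 2 to compound 3, is therefore unreadable, and the limit of > 30000 nM in this assay, at which 2 of the 3 values shown sit, is where two of the three values sit. Within the data shown here, compound 1 thus stands alone as the single readable value and cannot be ranked against compound 2 or compound 3 beyond saying that it gives a number where they give none.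

Compound 4 `CCn1c(-c2ccccc2)nc2c(N)ncnc21` differs from compound 1 by hydrogen in place of cyclohexyl on a nitrogen on an aromatic ring. Among the measured compounds shown here, no measured step bears on this change: compound 2 and compound 3 differ from compound 1 elsewhere, and both give only limits. The change removes the whole cyclohexyl and leaves an amino group, so the expectation is for weakening rather than gain. Compound 4 is expected to come out at 25000 nM, between 8000 nM and 80000 nM. That estimate means a step of a 2.8-fold higher number from compound 1 to compound 4 (0.44 log units; beyond the scatter), with a real chance that compound 4 reaches only a limit.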

Compound 4, inhibition constant: 3020 nM
Compound 4: middle estimate off by 8.3-fold (0.92 log units), on the high side; the whole stated range lies above it.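

In this assay, the cyclohexyl on this nitrogen is not required for a readable value: cutting cyclohexylamino back to amino gives a 3.0-fold lower number from compound 1 to compound 4 (0.48 log units; beyond the scatter). Going by these compounds alone, this is the first readable step in the set, and it shows that the change strengthens inhibition beyond the scatter, so the unsubstituted amino group serves at least as well here as the whole cyclohexyl ring. Nothing shown accounts for this step, and its cause stays unassigned.

Going by these compounds, only hydrogen and cyclohexyl can be compared at this nitrogen, so it remains open whether methyl, a longer chain such as n-butyl, or a benzyl group would fall on the same line or move the value further. The step between compound 2 and compound 3 cannot be read, and both compounds differ from compound 1 and compound 4 in more than one place, so they say nothing about this change: the limit of > 30000 nM in this assay, at which 2 of the 4 values shown sit.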